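Thiophen-2-yl in Place of 4-Hydroxyphenyl: Expected Cytotoxicity

This account rests on a few compounds, and the source may have more. Where it says the series, first, only, none or still open, it means among the compounds named here.

Compound 1, `O=C(O)c1ccc(C(=O)/C=C/c2ccc3c(c2)B(O)OC3)cc1`: in an ADME assay on L929 cells (Mus musculus) for cytotoxicity, read by resazurin assay, with a stated time of 72 h (a lower number here means a stronger inhibitor, a higher number a weaker inhibitor), compound 1 gives > 10 ug/mL, a limit of the assay.
Compound 2, `O=C(/C=C/c1ccc2c(c1)B(O)OC2)c1ccc(O)cc1`: compound 2 gives > 10 ug/mL, also a limit.
Compound 3, `CCc1ccc(C(=O)/C=C/c2ccc3c(c2)B(O)OC3)cc1`: compound 3 gives > 10 ug/mL, again a limit.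

Compound 2 therefore stands where every measured value stands, as the limit of > 10 ug/mL in this assay, at which 3 of the 3 values shown sit, shows; no number separates it from the others. The steps a step that the two limits leave unreadable from compound 1 to compound 2, a step that the two limits leave unreadable from compound 1 to compound 3 and a step that the two limits leave unreadable from compound 2 to compound 3 all lie between limits and carry no readable size.

Compound 4, `O=C(/C=C/c1ccc2c(c1)B(O)OC2)c1cccs1`, differs from compound 2 by thiophen-2-yl in place of 4-hydroxyphenyl on a carbonyl carbon. The measured steps, all unreadable, give no direction for this change, so no step beyond the scatter is expected in this assay: the estimated step is a step that the limit leaves unreadable from compound 2 to compound 4.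

Compound 4 is thus expected to give about 15 ug/mL, between 5 ug/mL and 45 ug/mL, most likely again reported only as a limit.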

Compound 4, half-maximal inhibitory concentration: > 10 ug/mL
Compound 4 gave a limit, no number; the forecaster's own chance of this, stated with the estimate: 70%; the middle value does not contradict the limit.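

Compound 2 and compound 4 are each reported only as a limit, so no size can be read for the step between them: the limit of > 10 ug/mL in this assay, at which 4 of the 4 values shown sit.

The compounds shown leave open how the groups compare in cytotoxicity, as none has an exact number.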